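A Ring Methyl Comes Off: From Compound 3 to Compound 4

The source may hold more compounds than are shown below. What is called first, only, known or untested is meant among the compounds shown, and "the series" means these compounds.

Three compounds built on one shared core were tested in a functional assay on cells for agonist activity at Free fatty acid receptor 1 (Rattus norvegicus), read by FLIPR and calcium flux; on this read-out higher numbers stand for an effect only at larger amounts of compound and lower numbers for an effect already at smaller amounts. Compound 1 `CC#C[C@@H](Cc1nnn[nH]1)c1ccc(OCc2ccc3scc(-c4ccc(OCCCS(C)(=O)=O)cc4C)c3c2)cc1` gives 9 nM, compound 2 `CC#C[C@@H](Cc1nnn[nH]1)c1ccc(OCc2ccc3scc(-c4cc(OCCOC)ccc4C)c3c2)cc1` gives 26 nM, and compound 3 `CC#C[C@@H](Cc1nnn[nH]1)c1ccc(OCc2ccc3sc(C)c(-c4ccc(OCCOC)cc4C)c3c2)cc1` gives 32 nM. Compound 3 holds the highest of the three numbers; its gap to compound 2 lies within the scatter, while compound 1 sits at a clearly lower number, beyond it. Compound 4 `CC#C[C@@H](Cc1nnn[nH]1)c1ccc(OCc2ccc3scc(-c4ccc(OCCOC)cc4C)c3c2)cc1` has not yet been measured. It differs from compound 3 by hydrogen in place of methyl on an aromatic carbon, a hydrogen in place of methyl on an aromatic carbon. For the measured compounds named here, no measured pair isolates this change, so the step expected here is a 1.5-fold lower number from compound 3 to compound 4 (0.16 log units; within the scatter), within the usual scatter. Compound 4 is therefore estimated to give about 22 nM in this assay, with a range from 7 nM to 65 nM.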

Compound 4, half-maximal effective concentration: 4 nM
The estimate for compound 4 lay 5.5-fold (0.74 log units) above the measured number; the measured number lies below the stated range.
By their numbers in this assay, from the lowest: compound 4; then compound 1; then compounds 2 and 3 (each within the scatter of the next).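

Taking the methyl off this aromatic carbon gives an 8.0-fold lower number from compound 3 to compound 4 (0.90 log units; beyond the scatter) in this assay, so on this core hydrogen is clearly favoured over methyl at this position. With hydrogen in place, the phenyl substituent also counts: 4-(2-methoxyethoxy)-2-methylphenyl in place of 5-(2-methoxyethoxy)-2-methylphenyl gives a 6.5-fold lower number from compound 2 to compound 4 (0.81 log units; beyond the scatter), and methoxy in place of (methylsulfonyl)methyl gives a 2.3-fold lower number from compound 1 to compound 4 (0.35 log units; beyond the scatter). Nothing available accounts for the size of the methyl step. Going by these compounds, whether chlorine, ethyl or methoxy on this carbon would match hydrogen remains open. So does whether removing the methyl gives a similar step when the chain carries (methylsulfonyl)methyl.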